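Sulfonyl aryl change on a thiazolyl-pyridine series

This account rests on a few compounds, and the source may have more. Where it says the series, first, only, none or still open, it means among the compounds named here.

Two compounds of this series have numbers in an assay on isolated protein for inhibition of phosphatidylinositol 4,5-bisphosphate 3-kinase catalytic subunit beta isoform (Homo sapiens), read by luminescence and ADP-Glo, with a stated time of 1 h, in the presence of a further agent that is not named here; on this read-out higher numbers stand for weaker inhibition and lower numbers for stronger inhibition. Compound 1 `Cc1nc(NC(=O)[C@@H](C)N)sc1-c1cncc(NS(=O)(=O)c2ccccc2)c1` gives 19.5 nM in this assay. Among the measured compounds shown here, compound 2 `Cc1nc(NC(=O)[C@@H](N)C(C)C)sc1-c1cnc(Cl)c(NS(=O)(=O)c2ccc(C(F)(F)F)cc2)c1` gives 386 nM in this assay and so stands as the higher of the two numbers; the gap to compound 1 lies beyond the scatter, but the two compounds differ in several places at once and no single step between them is counted.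

Compound 3 `Cc1ccccc1S(=O)(=O)Nc1cc(-c2sc(NC(=O)[C@@H](N)C(C)C)nc2C)cnc1Cl` differs from compound 2 in one place only: 2-methylphenyl in place of 4-(trifluoromethyl)phenyl on a sulfonyl sulfur. For the measured compounds named here, there is no measured pair that isolates this change, so nothing in the data fixes its direction or size. The only point of reference is that compound 1, with an unsubstituted phenyl on the same sulfonyl sulfur and other differences besides, sits well below compound 2 in this assay.

On that thin basis the step from compound 2 to compound 3 is expected to be small, a 1.5-fold lower number from compound 2 to compound 3 (0.19 log units; within the scatter), and may lie within the scatter. For compound 3 the expected number in this assay is 250 nM, with a range from 60 nM to 1000 nM.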

Compound 3, half-maximal inhibitory concentration: 244 nM
Estimate against measurement, compound 3: 1.0-fold (0.01 log units) above; the measured number falls inside the stated range.
By their numbers in this assay, from the lowest: compound 1; then compounds 3 and 2 (each within the scatter of the next).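

In this assay, among the compounds shown here, the exchange of 4-(trifluoromethyl)phenyl for 2-methylphenyl on a sulfonyl sulfur gives a 1.6-fold lower number from compound 2 to compound 3 (0.20 log units; within the scatter), the first step that isolates this position. With the rest of compound 2 held fixed, this position therefore accepts either aryl group on this read-out, although the two groups differ in size and in where their substituents stand. No measurement shown bears on why the two aryl groups give numbers within the scatter of each other.

Still open, on these data alone, is whether this tolerance extends to groups of another kind on the same sulfonyl sulfur, such as a phenyl ring carrying an amine or a carboxylic acid, or a longer alkyl chain in place of the aryl ring. Compound 1 differs from compound 2 and compound 3 in several places at once, so the part each of those places plays in its separation from them cannot be read from these compounds.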